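Working notes: thiophene swapped for butyl, growth inhibition

A few compounds are considered here, and "the series" means these few. Any claim that something is new, unique, unknown or untested is made for them only; others in the source may bear on it.

Measured so far:
compound 1 `c1ccc(-n2cc3cnc(-c4ccsc4)cc3n2)cc1` — 8300 nM
compound 2 `Cc1nc(CCO)cc2nn(-c3ccccc3)cc12` — > 100000 nM

Among the compounds with values here, in a functional assay on K562 cells (Homo sapiens) for inhibition, read by fluorescence, with a stated time of 72 h (on this read-out lower numbers stand for stronger inhibition of growth and higher numbers for weaker inhibition of growth), compound 1 gives 8300 nM, the only number so far. Compound 2 reaches only a limit of the assay, > 100000 nM, which is where the limit of > 100000 nM in this assay, at which 1 of the 2 values shown sits, sits. Compound 3 `CCCCc1cc2nn(-c3ccccc3)cc2cn1` is yet unmeasured and differs from compound 1 in one place: butyl in place of thiophen-3-yl on an aromatic carbon. Within the data shown here, no step between measured compounds is available to anchor the change, so the size of the step is uncertain; a loss beyond the usual scatter is expected rather than a gain. Compound 3 is expected at 20000 nM, between 5000 nM and 100000 nM. The step of a 2.4-fold higher number from compound 1 to compound 3 (0.38 log units; beyond the scatter) is the expected loss.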

Compound 3, concentration for 50% growth inhibition: 6700 nM
Compound 3: middle estimate off by 3.0-fold (0.47 log units), on the high side, within the range that was stated.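

On the aromatic carbon next to the ring nitrogen, activity does not depend on a ring: in this assay, butyl in place of thiophen-3-yl gives a 1.2-fold lower number from compound 1 to compound 3 (0.09 log units; within the scatter) and so leaves the number within the scatter. In this pair, neither the five-membered aromatic ring nor its sulfur is required to hold the value. Still open, as far as these compounds go, is whether a longer chain, a carboxylic acid or an amine on this carbon would move the number beyond the scatter. No measured property shown here accounts for the step.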